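This account rests on a few compounds, and the source may have more. Where it says the series, first, only, none or still open, it means among the compounds named here.

Measured compounds:
compound 1, `N[C@]1(C(=O)O)[C@H]2[C@@H](C[C@H]1OCc1cccc(Cl)c1)[C@]2(F)C(=O)O`, 3.28 nM
compound 2, `N[C@]1(C(=O)O)[C@H]2[C@@H](C[C@H]1OCc1ccc3ccccc3c1)[C@]2(F)C(=O)O`, 2.53 nM

The set is measured in an assay on CHO cells for binding affinity to metabotropic glutamate receptor 2 (Rattus norvegicus); on this read-out lower numbers stand for stronger inhibition and higher numbers for weaker inhibition. Going by the values given here, compound 1 gives 3.28 nM, the higher of the two numbers recorded there; compound 2, the only other measured compound, gives 2.53 nM in this assay, and the gap between the two lies within the usual scatter of repeated measurements, so the two cannot be told apart. Among the compounds with values here, no step between measured compounds differing in a single place is available to lean on.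

Compound 3, `N[C@]1(C(=O)O)[C@H]2[C@@H](C[C@H]1OCc1cccs1)[C@]2(F)C(=O)O`, has not yet been measured in this assay. It is reached from compound 1 by a single change: thiophen-2-yl in place of 3-chlorophenyl on a saturated chain carbon bound to an oxygen on a saturated carbon. Within the data shown here, with no measured step to calibrate the change, the expectation rests on the values of compound 1 and compound 2 alone, which show that two different aromatic groups at this position give closely similar numbers. For compound 3 a small shift toward a weaker number is expected, corresponding to a step of a 1.7-fold higher number from compound 1 to compound 3 (0.22 log units; within the scatter), though a result within the scatter would not be surprising. The estimate for compound 3 in this assay is 5.5 nM, with a range from 2 nM to 15 nM.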

Compound 3, inhibition constant: 8.79 nM
Compound 3: the middle estimate sits 1.6-fold (0.20 log units) below what was measured; measured number inside the range.
By their numbers in this assay, from the lowest: compounds 2 and 1 (each within the scatter of the next); then compound 3.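

In this assay, going by these compounds alone, the exchange of 3-chlorophenyl for thiophen-2-yl on a saturated chain carbon bound to an oxygen on a saturated carbon gives a 2.7-fold higher number from compound 1 to compound 3 (0.43 log units; beyond the scatter), the first single change at this place that can be read. The values of compound 1 and compound 2 lay within the scatter of each other and so gave no sign that the aromatic group here could move the number; this step shows that it can, although the step is a modest one. No supporting measurement bears on why the number moved.

The change replaces a six-membered aromatic ring of carbon only, carrying a chlorine, with a five-membered aromatic ring holding one sulfur, so the compounds shown do not tell whether the loss of the chlorine, the smaller ring or the sulfur accounts for the step. A plain phenyl would part the chlorine from the ring, thiophen-3-yl or furan-2-yl would test the hetero atom and its placing, and a longer chain carrying the same ring remains an open question at this position.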